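This account rests on a few compounds, and the source may have more. Where it says the series, first, only, none or still open, it means among the compounds named here.

Measured so far in a functional assay on NALM-6 cells (Homo sapiens) for cytotoxicity, read by MTT assay, with a stated time of 46 h; on this read-out lower numbers stand for stronger inhibition and higher numbers for weaker inhibition:
- Compound 1 `O=C1/C(=C\c2ccccc2)C(c2ccccc2)Oc2ccccc21`: > 1000000 nM, a limit and not a number
- Compound 2 `O=C1/C(=C/c2ccc(Br)cc2)C(c2ccccc2)Oc2ccccc21`: 6900 nM

Among the compounds with values here, compound 2, at 6900 nM, holds the only true number in this assay. The result for compound 1 is a limit. Compound 3 `O=C1/C(=C\c2ccc(Br)cc2)C(c2ccccc2)Oc2ccccc21` differs from compound 2 only in geometry: the two compounds have the same atoms and bonds; at least one stereo element is drawn with a configuration in one of them and without one in the other: 1 of 2 stereo elements differ; a double bond is drawn E in compound 2 and Z in compound 3. Within the data shown here, no measured pair shows what such a change does, so the expectation rests on compound 2 at 6900 nM. The estimated step is a 1.4-fold higher number from compound 2 to compound 3 (0.16 log units; within the scatter), which would stay within the usual scatter, though with wide uncertainty. Compound 3 is expected at 10000 nM, with an estimated range of 2000 nM to 50000 nM.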

Compound 3, half-maximal inhibitory concentration: > 1000000 nM
Compound 3: no number, only a limit; the forecaster's own chance of this, stated with the estimate: 15%; middle value at least 100-fold (2.00 log units) from the limit.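

In this assay, the geometry of the double bond alone now proves decisive, with an at least 140-fold higher number from compound 2 to compound 3 (2.16 log units; beyond the scatter). Compound 3 carries the same bromo group as compound 2, so that group does not by itself secure a measured number. The step between compound 1 and compound 3 cannot be read: the limit of > 1000000 nM in this assay, at which 2 of the 3 values shown sit.

The compounds shown leave open whether a methoxy group or an amine in place of the bromo group would give a number with either geometry. The drawing of the pair also leaves a caution on how the step is read: the fact that one of compounds 2 and 3 is drawn with a defined configuration and the other without, at the place where they differ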